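Trifluoromethyl in place of hydrogen on compound 2

The compounds below may be only part of what the source reports. "The series", "measured", "known", "first", "only" and "open" are said of these compounds alone.

Going by the values given here, in a physicochemical assay for solubility, at pH 7.4 (a lower number here means a less soluble compound, a higher number a more soluble compound), compound 1 (`Cc1cc(NC(=O)Nc2ccc(F)cc2)c2ccccc2n1`) gives 3700 nM, while compound 2 (`Cc1cc(NC(=O)Nc2ccc(O)cc2)c2ccccc2n1`) gives 100 nM, the lower of the two numbers so far. Among the compounds with values here, only one measured step bears on what follows: a 37-fold lower number from compound 1 to compound 2 (1.57 log units; beyond the scatter), a large change beyond the scatter, made by hydroxy replacing fluoro on an aromatic carbon. Compound 3 (`Cc1cc(NC(=O)Nc2ccc(OC(F)(F)F)cc2)c2ccccc2n1`) differs from compound 2 by having trifluoromethyl in place of hydrogen on an oxygen on an aromatic ring, that is, hydroxy to trifluoromethoxy: trifluoromethyl in place of hydrogen on an oxygen on an aromatic ring. Within the data shown here, no measured step covers this exact change, so the guide is indirect. Compound 3 has no hydroxy, and neither does compound 1 at 3700 nM, so a move upward is expected, though not necessarily the full distance. The expected change is a 6.0-fold higher number from compound 2 to compound 3 (0.78 log units; beyond the scatter). For compound 3 the estimate is 600 nM, with an expected range from 120 nM to 3500 nM.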

Compound 3, solubility: 300 nM
Beside the measured number, compound 3's estimate is 2.0-fold (0.30 log units) above it, within the range that was stated.
By their numbers in this assay, from the lowest: compound 2; then compound 3; then compound 1.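

In this assay there is a 3.0-fold higher number from compound 2 to compound 3 (0.48 log units; beyond the scatter) when trifluoromethyl replaces hydrogen on an oxygen on an aromatic ring, so changing what sits on this oxygen does move the number. Removing the hydroxy does not by itself restore the higher number, as there is still a 12-fold lower number from compound 1 to compound 3 (1.09 log units; beyond the scatter) when trifluoromethoxy replaces fluoro on an aromatic carbon, even though neither compound carries a hydroxy. Nothing at hand explains either step.

Going by these compounds, it remains open whether a methoxy, an amine or a carboxylic acid in this same place would give a number closer to that of compound 1 or that of compound 2. On these data alone, it is also open whether these steps would hold on a core other than the one shared here.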